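A Methyl Added Where Both Neighbours Sit at the Limit

The compounds below may be only part of what the source reports. "The series", "measured", "known", "first", "only" and "open" are said of these compounds alone.

Compound 1 `Cc1nc(C)c(-c2nn(-c3ccc(F)cc3)cc2/C=C/C(=O)c2cc(Br)ccc2O)s1` and compound 2 `Cc1nc(C)c(-c2nn(-c3ccc(F)cc3)cc2C2CC(c3cc(Cl)ccc3O)=NN2)s1` share a core and were both tested in an ADME assay on PANC-1 cells (Homo sapiens) for inhibition, read by MTT assay; on this read-out higher numbers stand for weaker inhibition of growth and lower numbers for stronger inhibition of growth. In this assay compound 1 gives only a limit of the assay, > 250 ug/mL, and not a number. Compound 2 likewise reaches only the limit in this assay, reading > 250 ug/mL. For the measured compounds named here, compound 2 therefore stands nowhere distinct: both known values sit at the same boundary (the limit of > 250 ug/mL in this assay, at which 2 of the 2 values shown sit), and no step between measured compounds can be drawn from them.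

Compound 3 `Cc1nc(C)c(-c2nn(-c3ccc(F)cc3)cc2C2CC(c3cc(Cl)c(C)cc3O)=NN2)s1` has not yet been measured. It differs from compound 2 by a single change, (methyl in place of hydrogen on an aromatic carbon), in words a methyl in place of hydrogen on an aromatic carbon. Going by the values given here, with no measured step to lean on, and with both known values resting at the limit (the limit of > 250 ug/mL in this assay, at which 2 of the 2 values shown sit), the expected step in this assay is a number no higher from compound 2 to compound 3 (the limit leaves the size open), which is to say none beyond the scatter. Compound 3 is accordingly estimated at 250 ug/mL, within a range from 100 ug/mL to 500 ug/mL, and most likely it will again be reported only as a limit.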

Compound 3, concentration for 50% growth inhibition: 127 ug/mL
Beside the measured number, compound 3's estimate is 2.0-fold (0.29 log units) above it; measured number inside the range.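

In this assay, the methyl on the 5-chloro-2-hydroxyphenyl ring gives an at least 1.9-fold lower number from compound 2 to compound 3 (0.29 log units; that floor lies within the scatter). Compound 3 is the only compound shown that returns a real number rather than a limit, so this aromatic carbon, ortho to a chloro group, meta to a hydroxy group and para to a large group, is a place where a single added methyl comes with a readable value. Even so, the step is only a floor, and its true size cannot be read because the starting point of compound 2 is a limit and not a number: the limit of > 250 ug/mL in this assay, at which 2 of the 3 values shown sit.

Only one replacement at this position is shown, so it stays open whether an amine, a methoxy group or a longer chain such as ethyl on the same carbon would give a lower number, a higher one or the limit again. Also open is whether the methyl itself matters here or any added group would do, since hydrogen and methyl are the only two groups shown at this carbon.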